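A few compounds are considered here, and "the series" means these few. Any claim that something is new, unique, unknown or untested is made for them only; others in the source may bear on it.

Compound 1 `CCN(CC)S(=O)(=O)c1ccc(S(=O)(=O)N2CCC[C@@H](C(=O)NC3CCOCC3)C2)cc1` gives 1350 nM in a functional assay on MIA PaCa-2 cells (Homo sapiens) for inhibition, read by MTT assay, with a stated time of 3 days; on this read-out lower numbers stand for stronger inhibition and higher numbers for weaker inhibition. Compound 2 `CCN(CC)S(=O)(=O)c1ccc(S(=O)(=O)N2CCC[C@@H](C(=O)N[C@@H]3CCOC3)C2)cc1` gives 100 nM in this assay.

Compound 2 therefore holds the lowest of the two numbers, with compound 1 next. Going by the values given here, the single measured step, a 14-fold lower number from compound 1 to compound 2 (1.13 log units; beyond the scatter), shows that the group on the amide nitrogen matters greatly. Compound 3 `CCN(CC)S(=O)(=O)c1ccc(S(=O)(=O)N2CCC[C@@H](C(=O)N3CCC(C(F)F)CC3)C2)cc1` carries 4-(difluoromethyl)piperidin-1-yl in place of (oxolan-3-yl)amino on a carbonyl carbon. Among the compounds with values here, no measured step covers this change, and the one known step gives no transferable direction; the donor is lost and the ring grows. A moderate rise in number is expected, a 4.0-fold higher number from compound 2 to compound 3 (0.60 log units; beyond the scatter). Compound 3 is estimated at 400 nM, between 80 nM and 2000 nM.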

Compound 3, half-maximal inhibitory concentration: 140 nM
Estimate against measurement, compound 3: 2.9-fold (0.46 log units) above, within the range that was stated.
By their numbers in this assay, from the lowest: compounds 2 and 3 (each within the scatter of the next); then compound 1.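

In this assay, 4-(difluoromethyl)piperidin-1-yl and (oxolan-3-yl)amino cannot be told apart on this carbonyl carbon, with a 1.4-fold higher number from compound 2 to compound 3 (0.15 log units; within the scatter), so a group with no hydrogen-bond donor or acceptor serves here as well as one that has them. Against (oxan-4-yl)amino the same group gives a 9.6-fold lower number from compound 1 to compound 3 (0.98 log units; beyond the scatter), so a six-membered ring on this carbonyl carbon does not by itself go with the high number of compound 1. Nothing at hand explains either step. On these data alone, what plain piperidin-1-yl or morpholin-4-yl would give here remains open, and with it whether the difluoromethyl group contributes anything.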